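A few compounds are considered here, and "the series" means these few. Any claim that something is new, unique, unknown or untested is made for them only; others in the source may bear on it.

Measured so far in an assay on HEK293 cells for displacement of a labelled ligand from Melanocortin receptor 4 (Homo sapiens); on this read-out lower numbers stand for stronger inhibition and higher numbers for weaker inhibition:

compound 1, `CCCCC(N)c1cc(C(F)(F)F)ccc1N1CCN(C(=O)CCc2ccc(Cl)cc2Cl)CC1`: 190 nM
compound 2, `COc1cc(OC)c(OC)cc1CCC(=O)N1CCN(c2ccc(C(F)(F)F)cc2[C@@H](N)CC(C)C)CC1`: 6100 nM

Compound 1 holds the lowest of the two numbers. In this assay, going by the values given here, compound 2 gives 6100 nM, a number far above that of compound 1 and well outside the usual scatter; compound 2 differs from compound 1 in more than one place, so no single step between them is defined and nothing beyond the two values themselves is taken from the pair.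

Compound 3, `COCCN[C@@H](CC(C)C)c1cc(C(F)(F)F)ccc1N1CCN(C(=O)CCc2ccc(Cl)cc2Cl)CC1`, is not yet measured. It keeps the rest of compound 1 and differs from it in one place: 1-((2-methoxyethyl)amino)-3-methylbutyl in place of 1-aminopentyl on an aromatic carbon

Among the compounds with values here, no measured step of this kind exists, so the expectation rests on compound 1 alone. The step of a 1.7-fold higher number from compound 1 to compound 3 (0.23 log units; within the scatter) is expected to be small and toward a higher number, quite possibly within the scatter. Compound 3 is estimated at 320 nM in this assay, with a range from 70 nM to 1500 nM.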

Compound 3, inhibition constant: 620 nM
Estimate against measurement, compound 3: 1.9-fold (0.29 log units) below; the range from low to high includes it.
By their numbers in this assay, from the lowest: compound 1; then compound 3; then compound 2.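

In this assay, going by these compounds alone, 1-((2-methoxyethyl)amino)-3-methylbutyl in place of 1-aminopentyl gives a 3.3-fold higher number from compound 1 to compound 3 (0.51 log units; beyond the scatter) and is the first step that can be read at a single place, on an aromatic carbon ortho to a large group and meta to a trifluoromethyl group. This place therefore accepts a group of 10 heavy atoms in place of one of 6, with an added oxygen and a defined stereocentre, at a modest loss beyond the scatter, so binding is weakened but not lost. No measurement at hand bears on the origin of this step.

The entering group differs from the leaving one in its chain, in the 2-methoxyethyl on the nitrogen and in the defined stereocentre, and the compounds shown do not separate these contributions. A free 1-amino-3-methylbutyl group at this place would separate the chain from the nitrogen substituent, while a 2-hydroxyethyl or a plain ethyl on the nitrogen would show what the ether oxygen contributes.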